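Replacing the Side Chain of Compound 2

The compounds below may be only part of what the source reports. "The series", "measured", "known", "first", "only" and "open" are said of these compounds alone.

In an ADME assay on HepG2 cells (Homo sapiens) for cytotoxicity (a lower number here means that less compound is tolerated, a higher number that more compound is tolerated), compound 1 (`CN(C)CC#Cc1cc2ncnc(Nc3ccc(OCc4cccc(F)c4)c(Cl)c3)c2s1`) reads > 32 uM, which is a limit and not a number. Among the measured compounds shown here, compound 2 (`Fc1cccc(COc2ccc(Nc3ncnc4cc(C#CCN5CCCC5)sc34)cc2Cl)c1`) gives 4.9 uM, the only true number so far. Compound 3 (`CC(C)(C)OC(=O)N1CCC[C@H]1C#Cc1cc2ncnc(Nc3ccc(OCc4cccc(F)c4)c(Cl)c3)c2s1`) carries 1-(tert-butoxycarbonyl)pyrrolidin-2-yl in place of (pyrrolidin-1-yl)methyl on a triple-bonded carbon. For the measured compounds named here, one measured step bears on this change: an at least 6.5-fold lower number from compound 1 to compound 2 (0.81 log units; beyond the scatter), a swap in the same side chain, which shows that this assay responds to changes there. A rise is therefore expected, though a smaller one, and the expected move is a 2.7-fold higher number from compound 2 to compound 3 (0.42 log units; beyond the scatter). Compound 3 is estimated at 13 uM, within an expected range of 5 uM to 32 uM.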

Compound 3, half-maximal toxic concentration: > 26 uM
Compound 3 was reported as a limit (the forecaster's own chance of this, stated with the estimate: 30%); middle value at least 2.0-fold (0.30 log units) from the limit.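

In this assay the value of compound 3 is a limit and not a number: the limit of > 26 uM in this assay, at which 1 of the 3 values shown sits. The change on the triple-bonded carbon can still raise the read-out, with an at least 5.3-fold higher number from compound 2 to compound 3 (0.72 log units; beyond the scatter), so compound 2 now reads lower than both of the other compounds, each of which sits at a limit. The step between those two cannot be read. From the compounds shown here alone, whether the rise follows the tert-butoxycarbonyl group or the attachment through the pyrrolidine ring carbon stays open. So does the reading of a pyrrolidin-2-yl group with a free ring amine.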